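A few compounds are considered here, and "the series" means these few. Any claim that something is new, unique, unknown or untested is made for them only; others in the source may bear on it.

Among the compounds with values here, in a functional assay on DU-145 cells (Homo sapiens) for cytotoxicity (on this read-out lower numbers stand for stronger inhibition of growth and higher numbers for weaker inhibition of growth), compound 1 `COc1ccc(C2=C(c3ccc(SC)cc3)CC3CCCN3C2=O)cc1Br` gives 900 nM, the second highest of the three numbers measured so far; compound 2 `CSc1ccc(C2=C(c3ccc(F)c(F)c3)C(=O)N3CCCC3C2)cc1` gives 500 nM, and compound 3 `CSc1ccc(C2=C(c3ccc(O)c(O)c3)C(=O)N3CCCC3C2)cc1` gives 60000 nM. Going from compound 1 to compound 2 brought a 1.8-fold lower number from compound 1 to compound 2 (0.26 log units; within the scatter), while the change to compound 3 brought a 67-fold higher number from compound 1 to compound 3 (1.82 log units; beyond the scatter). Compound 4 `CSc1ccc(C2=C(c3ccc(F)cc3)C(=O)N3CCCC3C2)cc1` has not yet been measured. It differs from compound 1 in one place: 4-fluorophenyl in place of 3-bromo-4-methoxyphenyl on a double-bonded ring carbon. The entering 4-fluorophenyl resembles the 3,4-difluorophenyl of compound 2 far more than the 3,4-dihydroxyphenyl of compound 3, so the step to compound 2 is the one that bears on it. Compound 4 is therefore expected to show no step beyond the scatter, a 1.4-fold lower number from compound 1 to compound 4 (0.14 log units; within the scatter). The value of compound 4 in this assay is estimated at 650 nM, within 250 nM to 1700 nM.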

Compound 4, concentration for 50% growth inhibition: 500 nM
The estimate for compound 4 lay 1.3-fold (0.11 log units) above the measured number; the range from low to high includes it.
By their numbers in this assay, from the lowest: compounds 2, 4 and 1 (each within the scatter of the next); then compound 3.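

In this assay, the 4-fluorophenyl group serves this double-bonded ring carbon as well as the 3-bromo-4-methoxyphenyl group does (a 1.8-fold lower number from compound 1 to compound 4 (0.26 log units; within the scatter)). Within the data shown here, removing one fluoro also leaves the read-out unmoved (no change at the digits printed from compound 2 to compound 4 (within the scatter)), so the second fluoro of compound 2 is not needed here, while the 3,4-dihydroxyphenyl group remains the one change that stands apart (a 120-fold lower number from compound 3 to compound 4 (2.08 log units; beyond the scatter)). Nothing available explains these steps.

On these data alone, it remains open whether a single hydroxy on this phenyl ring is enough to produce the large step seen with compound 3. The effect of an amine or a carboxylic acid there is also unknown.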